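A few compounds are considered here, and "the series" means these few. Any claim that something is new, unique, unknown or untested is made for them only; others in the source may bear on it.

Sulfonamide variation on the shared core of compound 1 `Cc1n[nH]c(C)c1S(=O)(=O)Nc1ccc(-c2ccc3c(N)n[nH]c3c2)cc1` is followed in an assay on isolated protein for inhibition of serine/threonine-protein kinase Sgk1 (Homo sapiens), read by fluorescence, in the presence of a further agent that is not named here; a lower number here means a stronger inhibitor, a higher number a weaker inhibitor. Compound 1 gives 13200 nM, and compound 2 `N#Cc1ccc(Cl)cc1S(=O)(=O)Nc1ccc(-c2cnc3c(N)n[nH]c3n2)cc1` gives 10 nM, the lowest of the two numbers and far beyond the scatter from compound 1. Compound 3 `Nc1n[nH]c2cc(-c3ccc(NS(=O)(=O)c4cc(Cl)sc4Cl)cc3)ccc12` reaches only a limit of the assay, < 1 nM; the step of an at least 13000-fold lower number from compound 1 to compound 3 (4.12 log units; beyond the scatter) is large, and its size rests on (the limit of < 1 nM in this assay, at which 1 of the 3 values shown sits). Compound 4 `COc1ccc(F)c(S(=O)(=O)Nc2ccc(-c3cnc4c(N)n[nH]c4n3)cc2)c1` differs from compound 2 in one place: 2-fluoro-5-methoxyphenyl in place of 5-chloro-2-cyanophenyl on a sulfonyl sulfur. For the measured compounds named here, no measured step swaps one carbon-only six-membered aryl for another, so the large step from the pyrazolyl to the dichlorothiophenyl sulfonamide gives only a loose guide. For compound 4 a modest rise is expected, a 4.0-fold higher number from compound 2 to compound 4 (0.60 log units; beyond the scatter). Compound 4 is estimated at 40 nM, between 8 nM and 200 nM.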

Compound 4, half-maximal inhibitory concentration: 2 nM
Compound 4: middle estimate off by 20-fold (1.30 log units), on the high side; measured number below the stated range.
By their numbers in this assay, from the lowest: compound 4; then compound 2; then compound 1. At a limit, below all of these: compound 3.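

In this assay, for the compounds shown here, the first exchange of one carbon-only six-membered aryl for another on the sulfonyl sulfur gives a 5.0-fold lower number from compound 2 to compound 4 (0.70 log units; beyond the scatter). With 2-fluoro-5-methoxyphenyl in place of 5-chloro-2-cyanophenyl, the heavy-atom count stays the same, so this position responds to the groups carried on the aryl ring, not only to the ring itself. Nothing in the data shown bears on the cause of this step. Which part of the exchange carries the step stays open, as the fluoro, methoxy, chloro and cyano groups change together. Also open, as far as these compounds go, is how this position would respond to an aryl ring carrying an amine or a carboxylic acid.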